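The source may hold more compounds than are shown below. What is called first, only, known or untested is meant among the compounds shown, and "the series" means these compounds.

Measured compounds:
Compound 1 `CN(C)CCCNc1ccc(C(=O)C2CC2c2ccc(Cl)cc2)cc1`: 15.8 ug/mL
Compound 2 `CCCCCCCCCCCCNc1ccc(C(=O)C2CC2c2ccc(Cl)cc2)cc1`: 386 ug/mL

In an ADME assay on Vero cells (Chlorocebus sabaeus) for cytotoxicity, with a stated time of 72 h (on this read-out higher numbers stand for lower toxicity in this test and lower numbers for higher toxicity in this test), compound 1 gives 15.8 ug/mL, the lower of the two numbers. Compound 3 `O=C(c1ccc(N2CCCC2)cc1)C1CC1c1ccc(Cl)cc1` differs from compound 1 as follows: pyrrolidin-1-yl in place of (3-(dimethylamino)propyl)amino on an aromatic carbon. It has pyrrolidin-1-yl in place of (3-(dimethylamino)propyl)amino on an aromatic carbon. Among the measured compounds shown here, only one measured step bears on this change, and it was large: a 24-fold higher number from compound 1 to compound 2 (1.39 log units; beyond the scatter). That step also removes dimethylamino, but it is a different change, so a smaller rise in this assay is expected. The expected step is a 5.1-fold higher number from compound 1 to compound 3 (0.70 log units; beyond the scatter). For compound 3 the estimated value is 80 ug/mL, with an expected range of 20 ug/mL to 320 ug/mL.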

Compound 3, half-maximal cytotoxic concentration: 431 ug/mL
Compound 3: the middle estimate sits 5.4-fold (0.73 log units) below what was measured, outside the stated range (above it).
By their numbers in this assay, from the lowest: compound 1; then compounds 2 and 3 (each within the scatter of the next).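

Swapping (3-(dimethylamino)propyl)amino for pyrrolidin-1-yl on this aromatic carbon gives a 27-fold higher number from compound 1 to compound 3 (1.44 log units; beyond the scatter) in this assay and shows that a long chain is not needed for a high number here. A small ring that has no hydrogen-bond donor does as well, and compounds 2 and 3 lie within the scatter of each other. Nothing available explains the rise. From the compounds shown here alone, it stays open whether losing the dimethylamino group alone accounts for the step. A simple propylamino chain, or a piperidine or morpholine ring at this carbon, could help separate these possibilities.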